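Swapping the aryl group on a hydrazide pair

The compounds below may be only part of what the source reports. "The series", "measured", "known", "first", "only" and "open" are said of these compounds alone.

Three compounds have been measured in a functional assay on OVCAR-3 cells (Homo sapiens) for antiproliferative activity, read by MTT assay, with a stated time of 24 h; on this read-out higher numbers stand for weaker inhibition and lower numbers for stronger inhibition:

Compound 1, `CCCCOc1ccc(C(=O)NNC(=O)c2ccc(NS(=O)(=O)c3cnc(O)nc3O)cc2)cc1`: 12800 nM
Compound 2, `Cc1ccccc1C(=O)NNC(=O)c1ccc(NS(=O)(=O)c2cnc(O)nc2O)cc1`: > 20000 nM
The value of compound 2 is a limit of the assay, not a number; it is the limit described as the limit of > 20000 nM in this assay, at which 1 of the 3 values shown sits.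
Compound 3, `CCCCOc1ccc(C(=O)NNC(=O)c2ccccc2NS(=O)(=O)c2cnc(O)nc2O)cc1`: 5010 nM

Compound 1 and compound 2 differ at one place: 2-methylphenyl in place of 4-butoxyphenyl on a carbonyl carbon. In this assay this gave an at least 1.5-fold higher number from compound 1 to compound 2 (0.19 log units; that floor lies within the scatter), so the direction is toward weaker inhibition, though how far is not settled. Compound 3 carries the same atoms as compound 1 joined differently; the difference between the two cores is not broken down here. Compound 3 gives the lowest number of the two measured numbers in this assay, beyond the scatter from compound 1.

Compound 4, `Cc1ccccc1C(=O)NNC(=O)c1ccccc1NS(=O)(=O)c1cnc(O)nc1O`, has not yet been measured. It differs from compound 3 as 2-methylphenyl in place of 4-butoxyphenyl on a carbonyl carbon, the same change that separates compound 1 from compound 2, at the same kind of carbonyl carbon. The expectation rests on that earlier change, where compound 1 gave 12800 nM. Compound 2, by contrast, reached only a limit, so a move toward weaker inhibition is anticipated, with a real chance that compound 4 also reaches the limit. The step expected from the measured parent is a 2.4-fold higher number from compound 3 to compound 4 (0.38 log units; beyond the scatter). Compound 4 is therefore estimated at 12000 nM, with a likely range from 4500 nM to 40000 nM.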

Compound 4, half-maximal inhibitory concentration: > 20000 nM
Compound 4: only a limit was reported (the forecaster's own chance of this, stated with the estimate: 35%); at least 1.6-fold (0.22 log units) between middle value and limit.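

In this assay, putting 2-methylphenyl in place of 4-butoxyphenyl on the carbonyl carbon of the core of compound 3 gave an at least 3.9-fold higher number from compound 3 to compound 4 (0.60 log units; beyond the scatter). On these data alone, both cores moved toward weaker inhibition with this change, so its direction carried over, although only the newer step is firmly beyond the usual scatter, and the two steps cannot be told apart in size: the same change on two cores in this assay, an at least 1.5-fold higher number (0.19 log units; that floor lies within the scatter) from compound 1 to compound 2 and an at least 3.9-fold higher number (0.60 log units; beyond the scatter) from compound 3 to compound 4; the limit leaves it open whether they differ Compound 4 gives > 20000 nM, which is a limit of the assay and not a number, so the true size of this step remains unknown, and nothing here shows that the change costs more on one core than on the other.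

The compounds shown place only two groups on this carbonyl carbon, so it stays open how a longer alkoxy chain than butoxy, an amine or a carboxylic acid on the aryl ring would behave on either core. As far as these compounds go, it is also open whether the two cores would respond alike to a replacement for 4-butoxyphenyl that gave measured numbers on both, since only such a pair could put a real size on the comparison.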